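The source may hold more compounds than are shown below. What is called first, only, known or untested is meant among the compounds shown, and "the series" means these compounds.

In a functional assay on TSGH cells (Homo sapiens) for inhibition, with a stated time of 72 h (on this read-out lower numbers stand for stronger inhibition and higher numbers for weaker inhibition), compound 1 `COc1cc(C(=O)c2cccc3c2ccn3C)cc(OC)c1OC` gives 26.9 nM, while compound 2 `CCCn1ccc2cc(C(=O)c3cc(OC)c(OC)c(OC)c3)ccc21` gives 1500 nM. That is the higher of the two numbers, so compound 2 is the weaker inhibitor, and the gap lies beyond the usual scatter. Compound 3 `COc1cc(C(=O)c2ccc3c(ccn3CCC(=O)O)c2)cc(OC)c1OC` has not yet been measured. It keeps the core of compound 2 and differs only at the end of the chain on the aromatic nitrogen: carboxy in place of methyl on a saturated chain carbon, two bonds along the chain from an aromatic nitrogen. In words, carboxy stands in place of methyl on a saturated chain carbon, two bonds along the chain from an aromatic nitrogen, turning propyl into 2-carboxyethyl. Among the measured compounds shown here, no measured pair shows this change, so any forecast is a judgement. A rise in the number beyond the scatter, meaning weaker inhibition, is expected, with an estimated size of a 4.0-fold higher number from compound 2 to compound 3 (0.60 log units; beyond the scatter). For compound 3 the expected value is 6000 nM, with an estimated range from 1500 nM to 30000 nM.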

Compound 3, half-maximal inhibitory concentration: > 10000 nM
Compound 3: a limit, no number; the forecaster's own chance of this, stated with the estimate: 30%; at least 1.6-fold (0.22 log units) between middle value and limit.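

Compound 3 gives > 10000 nM in this assay, which is a limit of the assay and not a number: the limit of > 10000 nM in this assay, at which 1 of the 3 values shown sits. Turning propyl into 2-carboxyethyl therefore brings an at least 6.6-fold higher number from compound 2 to compound 3 (0.82 log units; beyond the scatter), and the true size of this step could be larger still. Among the compounds shown here, this is the first evidence on the chain on the aromatic nitrogen itself: compound 2 was already a weak inhibitor, yet carboxy in place of methyl, two bonds along the chain from that nitrogen, weakens inhibition further.

A single step cannot show whether an amine, a methyl ester or a longer chain ending in carboxy would behave the same way at this position. It also leaves open whether this change would have a similar effect on a different core.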